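The source may report more compounds than this note shows. Statements on the series, on what has been measured and on what is new or still open speak of the compounds shown alone.

Measured compounds in an assay for inhibition of Polyunsaturated fatty acid 5-lipoxygenase (Homo sapiens), read by spectrophotometry, tested at 10 uM; a lower number here means less inhibition, a higher number more inhibition at the concentration tested (going by the name of the read-out):

compound 1 `COc1ccc(-c2nc(N3CCCCC3)sc2C(=O)c2ccccc2)cc1` gives 62%
compound 2 `O=C(NC(=S)N(c1ccccc1)c1ccccc1)c1ccccc1` gives 73.3%
compound 3 `COc1ccc(C(=O)NC(=S)N(c2ccccc2)c2ccccc2)cc1` gives 19.2%

Compound 3 stands lowest of the three numbers. Its nearest neighbour is compound 1, whose number lies higher beyond the scatter; the furthest is compound 2, higher again beyond the scatter. Going by the values given here, the one step measured, a number 54.1 percentage points lower from compound 2 to compound 3 (beyond the scatter), is large and downward: methoxy in place of hydrogen on an aromatic carbon cut the inhibition sharply.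

Compound 4 `O=C(NC(=S)N(c1ccccc1)c1ccccc1)c1ccc([N+](=O)[O-])cc1` is not yet measured. It differs from compound 3 as follows:

nitro in place of methoxy on an aromatic carbon

Among the compounds with values here, no measured step covers nitro in place of methoxy, so only the step from compound 2 to compound 3 bears on the case, and it bears indirectly: it shows that a group at this aromatic carbon, para to a large group, can move this assay by a large amount, but it says nothing about the direction a nitro would take relative to a methoxy. The expected step of a number 15.8 percentage points higher from compound 3 to compound 4 (beyond the scatter) is therefore set as a modest rise from the low number of compound 3, with a wide range that reaches towards the number of compound 2 at its upper end and stays near compound 3 at its lower end. For compound 4 the estimate is 35%, between 8% and 65%.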

Compound 4, a percentage reported as inhibition, at one concentration (the size of the read-out at that concentration, not a potency): 30.9%
For compound 4 the middle estimate is 4.1 percentage points above the measured one; the measured number falls inside the stated range.
By their numbers in this assay, from the lowest: compound 3; then compound 4; then compound 1; then compound 2.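

In this assay, the nitro group at this aromatic carbon, para to a large group, also gives a large loss, with a number 42.4 percentage points lower from compound 2 to compound 4 (beyond the scatter), so the sharp drop is no longer seen with methoxy alone. Compounds 3 and 4 both lie well under compound 2, and a number 54.1 percentage points lower from compound 2 to compound 3 (beyond the scatter) is of the same large order, so among these three compounds the unsubstituted benzoyl end gives the highest number, and neither substituted compound goes against this. The choice of group still counts, though to a lesser degree, with a number 11.7 percentage points higher from compound 3 to compound 4 (beyond the scatter), and nothing shown explains either the shared loss or this smaller gap between the two groups.

Whether any group at this carbon can keep the number of compound 2 remains open, since only methoxy and nitro are shown here; a fluorine atom, an amine or a carboxylic acid would test this. Also open is whether the loss belongs to this place alone, as the same groups on other carbons of this ring do not appear among these compounds.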